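Piperazine for Dimethylamine on the Triazole Arm of Compound 2

A few compounds are considered here, and "the series" means these few. Any claim that something is new, unique, unknown or untested is made for them only; others in the source may bear on it.

Among the measured compounds shown here, compound 2 `CN(C)Cc1cn(-c2ccccc2C(=O)NCCCCCCCn2cc(-c3cccnc3)nn2)nn1` gives 42.4 nM in an assay for inhibition of Nicotinamide phosphoribosyltransferase (Mus musculus), read by fluorescence, with a stated time of 1 h, in the presence of a further agent that is not named here (on this read-out higher numbers stand for weaker inhibition and lower numbers for stronger inhibition), one of only two numbers recorded; the other belongs to compound 1 `O=C(NCCCCCCCn1cc(-c2cccnc2)nn1)c1ccccc1-c1cccnc1`, which gives 28.5 nM. For the measured compounds named here, the single measured step, a 1.5-fold higher number from compound 1 to compound 2 (0.17 log units; within the scatter), lies within the scatter. Compound 3 `CN1CCN(Cc2cn(-c3ccccc3C(=O)NCCCCCCCn3cc(-c4cccnc4)nn3)nn2)CC1` carries 4-methylpiperazin-1-yl in place of dimethylamino on a saturated chain carbon bound to an aromatic carbon. Going by the values given here, no measured step touches this part of the structure, so the expectation rests only on the small size of the one step seen. Compound 3 is therefore expected to give about 50 nM, between 20 nM and 125 nM. The expected step of a 1.2-fold higher number from compound 2 to compound 3 (0.07 log units; within the scatter) is not beyond the scatter.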

Compound 3, half-maximal inhibitory concentration: 13.6 nM
Beside the measured number, compound 3's estimate is 3.7-fold (0.57 log units) above it; measured number below the stated range.
By their numbers in this assay, from the lowest: compound 3; then compounds 1 and 2 (each within the scatter of the next).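

The arm at this position is not indifferent to change: with (4-methylpiperazin-1-yl)methyl in place of (dimethylamino)methyl, this assay shows a step beyond the scatter (a 3.1-fold lower number from compound 2 to compound 3 (0.49 log units; beyond the scatter)). Among the compounds shown here, the earlier step, from compound 1 to compound 2, had stayed within the scatter, so this is the first sign that the amine on this saturated chain carbon matters to the number. Nothing available explains the shift. As far as these compounds go, whether it depends on the ring or on the second nitrogen stays open. A piperidine, a morpholine or a piperazine without its methyl would separate these.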